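From methylsulfanyl to cyano: notes on compound 4

The compounds below may be only part of what the source reports. "The series", "measured", "known", "first", "only" and "open" are said of these compounds alone.

Measured in a functional assay on MDA-MB-231 cells (Homo sapiens) for antiproliferative activity, read by MTT assay, with a stated time of 72 h; on this read-out lower numbers stand for stronger inhibition and higher numbers for weaker inhibition:
compound 1 `O=C(CCc1cccc2c1B(O)OC2)Nc1cccc(-c2cccc(F)c2)c1`: 570 nM
compound 2 `CSc1cccc(-c2cccc(NC(=O)CCc3cccc4c3B(O)OC4)c2)c1`: 150 nM
compound 3 `CSc1ccc(-c2cccc(NC(=O)CCc3cccc4c3B(O)OC4)c2)cc1`: 140 nM

Compound 3 sits level with compound 2, with a 1.1-fold lower number from compound 2 to compound 3 (0.03 log units; within the scatter). Both stand clear of compound 1, and the gap to compound 3 is a 4.1-fold lower number from compound 1 to compound 3 (0.61 log units; beyond the scatter).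

Next comes compound 4 `N#Cc1ccc(-c2cccc(NC(=O)CCc3cccc4c3B(O)OC4)c2)cc1`, with cyano in place of methylsulfanyl on an aromatic carbon, para to a large group (cyano in place of methylsulfanyl on an aromatic carbon). Among the measured compounds shown here, no measured compound carries cyano, so the evidence is indirect. For the measured compounds named here, the closest guide is a 3.8-fold lower number from compound 1 to compound 2 (0.58 log units; beyond the scatter), for methylsulfanyl in place of fluoro, a modest step like the one to compound 3. Going by the values given here, compound 1, the only measured compound without methylsulfanyl, gives 570 nM. Losing methylsulfanyl is therefore expected to raise the number in this assay modestly, though the direction remains uncertain. The expected step is a 2.1-fold higher number from compound 3 to compound 4 (0.33 log units; beyond the scatter). Compound 4 is estimated at 300 nM, with an expected range from 100 nM to 800 nM.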

Compound 4, half-maximal inhibitory concentration: 380 nM
Compound 4: the middle estimate sits 1.3-fold (0.10 log units) below what was measured; the measured number falls inside the stated range.
By their numbers in this assay, from the lowest: compounds 3 and 2 (each within the scatter of the next); then compounds 4 and 1 (each within the scatter of the next).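

In this assay, this aromatic carbon, para to a large group, proves sensitive to the choice of substituent: a 2.7-fold higher number from compound 3 to compound 4 (0.43 log units; beyond the scatter), whereas the earlier shift from 3-(methylsulfanyl)phenyl to 4-(methylsulfanyl)phenyl stayed within the scatter. The 4-cyanophenyl group also gives up the advantage held by compound 2, with a 2.5-fold higher number from compound 2 to compound 4 (0.40 log units; beyond the scatter), and it stands level with 3-fluorophenyl, with a 1.5-fold lower number from compound 1 to compound 4 (0.18 log units; within the scatter), so among these four compounds the lower numbers belong only to the two carrying methylsulfanyl. No measurement shown here accounts for this difference between the groups.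

Because 3-fluorophenyl and 4-cyanophenyl differ in both group and place, the effect of fluoro and cyano at a single position remains unresolved. On these data alone, it also remains open whether methoxy, an amine or a carboxylic acid on this carbon would track with methylsulfanyl or with cyano.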